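This account rests on a few compounds, and the source may have more. Where it says the series, first, only, none or still open, it means among the compounds named here.

Measured compounds:
Compound 1 `Cc1cc(S(=O)(=O)N2C=CNC(=O)[C@H]2CC(=O)N[C@H]2CCNCC2(C)C)c(C)cc1Cl`, in an in vitro functional assay on cells for antagonist activity at B1 bradykinin receptor (Homo sapiens), read by luminescence and calcium flux, with a stated time of 2 h (a lower number here means a stronger inhibitor, a higher number a weaker inhibitor), compound 1 gives 0.31 nM.
Compound 2 `Cc1cc(S(=O)(=O)N2C=CNC(=O)[C@H]2CC(=O)N2CC[C@H](N3CCCC3)C2)c(C)cc1Cl`, compound 2 gives 19 nM.
Compound 3 `Cc1cc(S(=O)(=O)N2C=CNC(=O)[C@H]2CC(=O)N2CCCC(N(C)C)CC2)c(C)cc1Cl`, compound 3 gives 2.7 nM.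

On these numbers compound 3 stands second highest of the three; the steps are an 8.7-fold higher number from compound 1 to compound 3 (0.94 log units; beyond the scatter) and a 7.0-fold lower number from compound 2 to compound 3 (0.85 log units; beyond the scatter). Compound 4 `Cc1cc(S(=O)(=O)N2C=CNC(=O)[C@H]2CC(=O)N2C[C@H]3CN(C)C[C@H]3C2)c(C)cc1Cl` differs from compound 3 in one place: a group of 9 heavy atoms (7 carbon, 2 nitrogen; 2 five-membered non-aromatic rings with 1 hetero atom each) in place of a group of 10 heavy atoms (8 carbon, 2 nitrogen; one seven-membered non-aromatic ring with 1 hetero atom), on a carbonyl carbon. Within the data shown here, two measured steps bear on this change. In a 7.0-fold lower number from compound 2 to compound 3 (0.85 log units; beyond the scatter) a seven-membered ring took the place of two five-membered rings and the number fell; in a 61-fold higher number from compound 1 to compound 2 (1.79 log units; beyond the scatter) two five-membered rings entered and the number rose. Both point the same way, so a modest rise in this assay, beyond the scatter, is expected for compound 4. The estimate for compound 4 is 10 nM, within 2.5 nM to 40 nM, an expected step of a 3.7-fold higher number from compound 3 to compound 4 (0.57 log units; beyond the scatter).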

Compound 4, half-maximal inhibitory concentration: 136 nM
Estimate against measurement, compound 4: 14-fold (1.13 log units) below; measured number outside the range, above it.
By their numbers in this assay, from the lowest: compound 1; then compound 3; then compound 2; then compound 4.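

Two five-membered rings do not settle the number at this position: two groups that both carry them still differ, with a 7.2-fold higher number from compound 2 to compound 4 (0.85 log units; beyond the scatter). Among these compounds, replacing the seven-membered ring costs far more than the earlier steps showed, with a 50-fold higher number from compound 3 to compound 4 (1.70 log units; beyond the scatter), and measured against the six-membered ring group the gap widens to a 440-fold higher number from compound 1 to compound 4 (2.64 log units; beyond the scatter). Nothing available explains why these groups differ so much. Open too is where a piperazine or an open-chain diamine on the same carbonyl carbon would fall among these numbers.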